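A Second Methoxy Group on Two Related Cores

The compounds below may be only part of what the source reports. "The series", "measured", "known", "first", "only" and "open" are said of these compounds alone.

Of the compounds shown here, three have been measured in a functional assay on CNE-2 cells (Homo sapiens) for antiproliferative activity, read by sulforhodamine B assay, with a stated time of 48 h; on this read-out lower numbers stand for stronger inhibition and higher numbers for weaker inhibition. Compound 1 `COc1ccc(/C=C/C(=O)c2ccccc2-c2cccc(F)c2)cc1` gives 73 nM in this assay. Compound 2 `COc1ccc(/C=C/C(=O)c2ccccc2-c2cccc(F)c2)cc1OC` carries one further group on the same core, and in this assay compound 2 gives 650 nM. The change from compound 1 to compound 2 is methoxy in place of hydrogen on an aromatic carbon, and it produced an 8.9-fold higher number from compound 1 to compound 2 (0.95 log units; beyond the scatter).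

Compound 3 `COc1ccc(C(=O)/C=C/c2ccccc2-c2ccc(F)cc2)cc1` is built from the same atoms as compound 1, joined differently; how the two cores differ is not broken down here. In this assay compound 3 gives 9000 nM, the highest of the three numbers, well beyond compound 2 and further still beyond compound 1.

Compound 4 `COc1ccc(C(=O)/C=C/c2ccccc2-c2ccc(F)cc2)cc1OC` has not yet been measured. It stands to compound 3 as compound 2 stands to compound 1: the change is methoxy in place of hydrogen on an aromatic carbon, the same change at the same kind of place. Among the compounds with values here, the only guide is the single earlier case, in which adding this group gave an 8.9-fold higher number from compound 1 to compound 2 (0.95 log units; beyond the scatter). Since the core of compound 3 differs from that of compound 1 in a way not broken down here, the step need not repeat exactly, but a higher number is expected. The step expected from compound 3 to compound 4 is a 4.4-fold higher number from compound 3 to compound 4 (0.65 log units; beyond the scatter). Compound 4 is therefore estimated to give 40000 nM in this assay, with a plausible range from 9000 nM to 150000 nM.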

Compound 4, half-maximal inhibitory concentration: 7600 nM
For compound 4 the middle estimate is 5.3-fold (0.72 log units) above the measured one; measured number below the stated range.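

In this assay, putting methoxy in place of hydrogen on an aromatic carbon gave a 1.2-fold lower number from compound 3 to compound 4 (0.07 log units; within the scatter), so on this core the added group produced no difference that can be told from the ordinary variation between repeated measurements. Set beside the earlier case, this shows that the size of the step measured on the core of compound 1 did not carry over to the core of compound 3, and so a step measured on one core in this series cannot simply be transferred to the other: the same change on two cores in this assay, an 8.9-fold higher number (0.95 log units; beyond the scatter) from compound 1 to compound 2 and a 1.2-fold lower number (0.07 log units; within the scatter) from compound 3 to compound 4, 11-fold (1.02 log units) apart, beyond the scatter of two such steps This does not show why the two cores respond differently, and with only one pair on each core it gives no general rule for the change, nor any sign of how a third core would respond.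

The compounds shown leave open how a hydroxyl group, an amine or a longer ether such as ethoxy would behave in place of this methoxy on either core. Within the data shown here, they also leave open which feature of the difference between the two cores decides whether the added group matters, a question that pairs changing only one feature of the core at a time could address.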